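The compounds below may be only part of what the source reports. "The series", "measured", "known", "first", "only" and "open" are said of these compounds alone.

Measured compounds:
Compound 1, `C/C(C(=O)NC1CC1)=C(/C)c1ccc(Br)cc1`: 100 mg/kg
Compound 2, `COc1ccc(/C(C)=C(/C)C(=O)NC2CC2)cc1`: 300 mg/kg
Compound 3, `C/C(C(=O)NC1CC1)=C(\C)c1ccc(Cl)cc1`: 170 mg/kg

All three were tested in a toxicity assay on the whole organism (strain Icem-CET (SPF Caw)) for cytotoxicity, with Mus musculus as the target; a lower number here means that less compound is needed, a higher number that more compound is needed for the effect. Compound 3 gives 170 mg/kg, the second highest of the three numbers. Its nearest neighbour is compound 1 with 100 mg/kg, and the furthest is compound 2 with 300 mg/kg, yet both gaps lie within the scatter, so the three compounds cannot be told apart on these numbers.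

The compound to be measured next is compound 4, `C/C(C(=O)NC1CC1)=C(\C)c1ccc(Br)cc1`. It differs from compound 3 in one place: bromo in place of chloro on an aromatic carbon. Going by the values given here, only one measured step is available, a 1.8-fold lower number from compound 2 to compound 3 (0.25 log units; within the scatter), and it concerns a different change, so it shows merely that exchanging one small group for another on this aromatic carbon gave a step within the scatter. Compound 1 already carries a bromo group, and its value of 100 mg/kg sits close to that of compound 3. On this basis no step beyond the scatter is expected in this assay for compound 4. The expected step for compound 4 is a 1.2-fold lower number from compound 3 to compound 4 (0.08 log units; within the scatter). Compound 4 is therefore estimated at 140 mg/kg, with a range from 70 mg/kg to 280 mg/kg.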

Compound 4, dose for half-maximal effect: 300 mg/kg
Compound 4: middle estimate off by 2.1-fold (0.33 log units), on the low side; measured number above the stated range.
By their numbers in this assay, from the lowest: compounds 1, 3, 2 and 4 (each within the scatter of the next, the first and the last beyond it).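

Going by these compounds alone, changing the group on this aromatic carbon, para to a large group, again gives no step that stands out in this assay: bromo in place of chloro gives a 1.8-fold higher number from compound 3 to compound 4 (0.25 log units; within the scatter), and bromo in place of methoxy gives no change at the digits printed from compound 2 to compound 4 (within the scatter). The only step beyond the scatter among these new comparisons, and a modest one, involves no change of group at all, since the double bond drawn E becomes one drawn Z: a 3.0-fold higher number from compound 1 to compound 4 (0.48 log units; beyond the scatter). This step can be tied to the double bond rather than to the group on the aromatic carbon because of one observation: the fact that compounds 1 and 4 differ only in the configuration as drawn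

Bromo provides the only pair of compounds here that differ in this way, so it remains open whether the configuration of the double bond shifts the number to a similar extent with chloro or methoxy on the aromatic carbon. Also open, as far as these compounds go, is how an amine or a carboxylic acid at this position would compare with chloro, bromo and methoxy in this whole-animal toxicity test.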